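This account rests on a few compounds, and the source may have more. Where it says the series, first, only, none or still open, it means among the compounds named here.

Within the data shown here, in a functional assay on HepG2 cells (Homo sapiens) for antiproliferative activity, read by XTT assay, with a stated time of 72 h (a lower number here means a stronger inhibitor, a higher number a weaker inhibitor), compound 1 `Cc1ncnc2c1c(I)cn2[C@@H]1O[C@H](CO)[C@@H](O)[C@H]1O` gives 3460 nM, the higher of the two numbers so far. Compound 2 `C#Cc1cn([C@@H]2O[C@H](CO)[C@@H](O)[C@H]2O)c2ncnc(N(C)C)c12` gives 1320 nM in this assay, a lower number that lies beyond the usual scatter. Compound 3 `Cc1ncnc2c1c(-c1cc3ccccc3o1)cn2[C@@H]1O[C@H](CO)[C@@H](O)[C@H]1O` differs from compound 1 in one place: 1-benzofuran-2-yl in place of iodo on an aromatic carbon. Among the measured compounds shown here, no measured pair with a comparable change is available, so the size of the step rests on guesswork alone. A step toward a lower number is expected, a 5.8-fold lower number from compound 1 to compound 3 (0.76 log units; beyond the scatter), somewhat larger than the scatter. Compound 3 is estimated to give 600 nM in this assay, within a range from 100 nM to 3500 nM.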

Compound 3, half-maximal inhibitory concentration: > 20000 nM
Compound 3: a limit, no number (the forecaster's own chance of this, stated with the estimate: 5%); middle value at least 33-fold (1.52 log units) from the limit.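

Putting 1-benzofuran-2-yl in place of iodo on this aromatic carbon does not strengthen the compound in this assay but weakens it, with an at least 5.7-fold higher number from compound 1 to compound 3 (0.76 log units; beyond the scatter) as the step. So the group on this carbon matters, and a group of 9 heavy atoms here can cost much of the activity of compound 1. The reading for compound 3 is a limit of the assay, not a number: the limit of > 20000 nM in this assay, at which 1 of the 3 values shown sits.

On these data alone, whether a single phenyl ring, an amine or a short alkyl chain on this carbon would keep that activity remains open.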